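The compounds below may be only part of what the source reports. "The series", "measured", "known", "first", "only" and "open" are said of these compounds alone.

Measured compounds in a functional assay (spleen, spleen) for activation, with Mus musculus as the target; a lower number here means that less compound is needed, a higher number that more compound is needed for the effect:
compound 1, `CCCSc1nc(N)c2nc(O)n(Cc3ccccc3)c2n1`, 0.01 uM
compound 2, `Nc1nc(SCc2ccccc2)nc2c1nc(O)n2Cc1ccccc1`, 0.1 uM
compound 3, `COc1nc2c(N)ncnc2n1Cc1ccccc1`, > 10 uM

Compound 3 gives only a limit in this assay, > 10 uM, not a number. the limit of > 10 uM in this assay, at which 1 of the 3 values shown sits, records where that limit sits. Compound 4, `Nc1ncnc2c1nc(Cl)n2Cc1ccccc1`, differs from compound 3 in one place: chloro in place of methoxy on an aromatic carbon. For the measured compounds named here, the only measured step, a 10-fold higher number from compound 1 to compound 2 (1.00 log units; beyond the scatter), concerns a different part of the shared core and does not bear on this change; no measured pair shows chloro in place of methoxy. Compounds 1 and 2 differ from compound 3 in more than one place, so they give no single-point guide either. The step from compound 3 to compound 4 is therefore expected to be a number no higher from compound 3 to compound 4 (the limit leaves the size open), with wide uncertainty. Compound 4 is estimated at 10 uM (1 uM to 100 uM), with a fair chance that this assay again reports only a limit.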

Compound 4, minimum effective concentration: > 10 uM
Compound 4 gave a limit, no number (the forecaster's own chance of this, stated with the estimate: 55%); the middle value sits exactly at the limit.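

Compound 3 and compound 4 both give only a limit, so chloro in place of methoxy yields no readable step: the limit of > 10 uM in this assay, at which 2 of the 4 values shown sit.

The compounds shown leave open how chloro and methoxy on this aromatic carbon compare in this assay.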